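A few compounds are considered here, and "the series" means these few. Any claim that something is new, unique, unknown or untested is made for them only; others in the source may bear on it.

Measured in a functional assay on HeLa cells (Homo sapiens) for inhibition, read by CCK-8 assay, with a stated time of 48 h; on this read-out lower numbers stand for stronger inhibition and higher numbers for weaker inhibition:
- Compound 1 `Cc1cc(C)cc(NC(=O)NCCNS(=O)(=O)c2ccc(-c3ccccc3Oc3ccc([N+](=O)[O-])c([N+](=O)[O-])c3)s2)c1`: 12000 nM
- Compound 2 `COc1cccc(NC(=O)NCCNS(=O)(=O)c2ccc(-c3ccccc3Oc3ccc([N+](=O)[O-])c([N+](=O)[O-])c3)s2)c1`: > 20000 nM (a limit)
- Compound 3 `COc1ccc(NC(=O)NCCNS(=O)(=O)c2ccc(-c3ccccc3Oc3ccc([N+](=O)[O-])c([N+](=O)[O-])c3)s2)cc1`: > 20000 nM (a limit)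

Among the compounds with values here, compound 1 carries the only true number in the set, 12000 nM. The other readings stop at the limit of > 20000 nM in this assay, at which 2 of the 3 values shown sit, so no ranking of compound 2 and compound 3 is possible.

The next compound is compound 4 `Cc1cc(C)cc(NC(=O)NCCNS(=O)(=O)c2ccc(-c3ccccc3Oc3ccc(N)cc3)s2)c1`, which differs from compound 1 at a single place: 4-aminophenyl in place of 3,4-dinitrophenyl on an oxygen on an aromatic ring. In short, 4-aminophenyl stands in place of 3,4-dinitrophenyl on an oxygen on an aromatic ring.

The measured steps all concern the other end of the molecule, the group on an amide-type nitrogen. They are an at least 1.6-fold higher number from compound 1 to compound 2 (0.22 log units; that floor lies within the scatter), an at least 1.6-fold higher number from compound 1 to compound 3 (0.22 log units; that floor lies within the scatter) and a step that the two limits leave unreadable from compound 2 to compound 3. None of them changes the group on the oxygen, so they give no direct size for this change and show only that the series reads weakly in this assay.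

Compound 4 is therefore expected to stay in the region of compound 1 at 12000 nM. A reading that reaches the limit of the assay would be no surprise. The expected step is a 1.3-fold higher number from compound 1 to compound 4 (0.10 log units; within the scatter), which means no step beyond the scatter.

For compound 4 the estimated value is 15000 nM, with an expected range from 6000 nM to 35000 nM.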

Compound 4, half-maximal inhibitory concentration: > 20000 nM
Compound 4 ended at the assay's limit; the forecaster's own chance of this, stated with the estimate: 40%; middle value at least 1.3-fold (0.12 log units) from the limit.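

In this assay, the group on the oxygen on an aromatic ring now has its first reading, and 4-aminophenyl in place of 3,4-dinitrophenyl gives an at least 1.6-fold higher number from compound 1 to compound 4 (0.22 log units; that floor lies within the scatter). Compound 4 gives > 20000 nM, which is a limit of the assay and not a number. This adds that replacing 3,4-dinitrophenyl with 4-aminophenyl at this position brings no sign of stronger inhibition, although the true size of the step stays unknown and the floor does not establish any loss, leaving most of the set at one limit: the limit of > 20000 nM in this assay, at which 3 of the 4 values shown sit.

Open, going by these compounds, is whether a phenyl carrying a single nitro group, an unsubstituted phenyl or a phenyl carrying a carboxylic acid on the same oxygen would give a true number rather than a limit. Also open, on these data alone, is whether 4-aminophenyl would read differently with a group other than 3,5-dimethylphenyl on the amide-type nitrogen, such as a longer alkyl chain.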